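The compounds below may be only part of what the source reports. "The series", "measured", "known", "first", "only" and "open" are said of these compounds alone.

Measured so far in a functional assay on MCF7 cells (Homo sapiens) for antiproliferative activity, read by MTT assay, with a stated time of 72 h; a lower number here means a stronger inhibitor, a higher number a weaker inhibitor:
Compound 1 `CC(C)(C)c1cn(C[C@H](O)[C@H]2OC(=O)C(OCc3ccccc3)=C2OCc2ccccc2)nn1` gives 730 nM.
Compound 2 `COc1ccc(-c2cn(C/C=C3\OC(=O)C(OCc4ccccc4)=C3OCc3ccccc3)nn2)cc1` gives 39100 nM.
Compound 3 `O=C1O[C@H]([C@@H](O)Cn2cc(-c3cc(F)cc(F)c3)nn2)C(OCc2ccccc2)=C1OCc1ccccc1` gives 27700 nM.

Compound 2 has the highest of these three numbers; compound 3 has the nearest value, within the scatter of that of compound 2, while compound 1 lies far lower. Going by the values given here, the only measured step, a 38-fold higher number from compound 1 to compound 3 (1.58 log units; beyond the scatter), is large. Compound 4 `Cc1ccc(-c2cn(C/C=C3\OC(=O)C(OCc4ccccc4)=C3OCc3ccccc3)nn2)cc1` differs from compound 2 by methyl in place of methoxy on an aromatic carbon. Among the compounds with values here, no measured step involves that kind of change: the step from compound 1 to compound 3 swaps a different group at a different place, so it offers no guide here. With nothing bearing on the change, no shift beyond the scatter is expected. Compound 4 is therefore estimated at 36000 nM, with a range from 12000 nM to 100000 nM, meaning an expected step of a 1.1-fold lower number from compound 2 to compound 4 (0.04 log units; within the scatter).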

Compound 4, half-maximal inhibitory concentration: > 100000 nM
Compound 4: a limit, no number; the forecaster's own chance of this, stated with the estimate: 15%; middle value at least 2.7-fold (0.44 log units) from the limit.
By their numbers in this assay, from the lowest: compound 1; then compounds 3 and 2 (each within the scatter of the next). At a limit, above all of these: compound 4.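

Methyl in place of methoxy on the aromatic ring gives an at least 2.5-fold higher number from compound 2 to compound 4 (0.40 log units; beyond the scatter), so the group at this place on the ring matters, and the earlier compounds had not tested it. From the compounds shown here alone, compound 4 gives > 100000 nM, which is a limit and not a number, so the full size of the step stays unknown: the limit of > 100000 nM in this assay, at which 1 of the 4 values shown sits.

Open, going by these compounds, is how an amine or a chlorine at this same place would read. Also open, on these data alone, is whether the change from 4-methoxyphenyl to 4-methylphenyl would have a similar effect on the hydroxyl-bearing chain of compound 3.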